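A few compounds are considered here, and "the series" means these few. Any claim that something is new, unique, unknown or untested is made for them only; others in the source may bear on it.

Working notes on the series. In an ADME assay on microsomes from liver (Homo sapiens) for metabolic stability, read by LC-MS, using NADPH, with a stated time of 10 min, tested at 0.1 uM (a higher number here means faster removal of the compound, a lower number slower removal), compound 1 `O=C(NCCCCn1cccn1)c1cccc(C2SCC(=O)N2c2ccccn2)c1` gives 82.1 mL.min-1.g-1. Compound 2 `O=C(NCCCCc1ccccc1)c1cccc(C2SCC(=O)N2c2cccc(F)c2)c1` gives 1840 mL.min-1.g-1 in this assay. Compound 3 `C#Cc1cccc(N2C(=O)CSC2c2cccc(C(=O)NCCCCc3ccccc3)c2)c1` gives 751 mL.min-1.g-1 in this assay, the second highest of the three numbers; its nearest neighbour is compound 2, its furthest compound 1. Among the measured compounds shown here, the single step that differs in one place, a 2.5-fold lower number from compound 2 to compound 3 (0.39 log units; beyond the scatter), is the only step in the set and concerns the group on the amide-type nitrogen in the ring, so it bears on the present change, though a different group enters here.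

Compound 4 `O=C(NCCCCc1ccccc1)c1cccc(C2SCC(=O)N2c2ccc(C3CC3)cc2)c1` is not yet measured in this assay. Relative to compound 3 the change is 4-cyclopropylphenyl in place of 3-ethynylphenyl on an amide-type nitrogen in a ring.

For the measured compounds named here, no measured pair shows this exact replacement. Going by the values given here, the one step available is modest, and the shared core and the rest of compound 3 are kept, so for compound 4 a step of about a 1.2-fold higher number from compound 3 to compound 4 (0.08 log units; within the scatter) is expected in this assay, likely within the scatter of compound 3 rather than a clear move in either direction. Compound 4 is therefore estimated at 900 mL.min-1.g-1 in this assay, with a range from 350 mL.min-1.g-1 to 2300 mL.min-1.g-1.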

Compound 4, intrinsic clearance in microsomes: 811 mL.min-1.g-1
For compound 4 the middle estimate is 1.1-fold (0.05 log units) above the measured one, within the range that was stated.
By their numbers in this assay, from the lowest: compound 1; then compounds 3 and 4 (each within the scatter of the next); then compound 2.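

In this assay, the exchange on the amide-type nitrogen in a ring gives a 1.1-fold higher number from compound 3 to compound 4 (0.03 log units; within the scatter), so 4-cyclopropylphenyl and 3-ethynylphenyl are not told apart at this place, although one brings a three-membered ring and the other a triple bond. Set against the 3-fluorophenyl of compound 2, the new group gives a 2.3-fold lower number from compound 2 to compound 4 (0.36 log units; beyond the scatter), in the same direction as a 2.5-fold lower number from compound 2 to compound 3 (0.39 log units; beyond the scatter), so both carbon-only groups shown here stand lower than compound 2. No measurement at hand accounts for these numbers.

The two groups differ both in identity and in where they sit on the phenyl ring, and the compounds shown do not separate the two. From the compounds shown here alone, how an amine or a carboxylic acid on this phenyl ring would read in this assay remains open.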